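Lengthening the amine-bearing chain of compound 3

The source may hold more compounds than are shown below. What is called first, only, known or untested is meant among the compounds shown, and "the series" means these compounds.

Compound 3 `COc1cc(/C=C/C(=O)Nc2ccccc2)ccc1OCCCCCCN(C)C` is one of three close relatives that share a core and differ only in the amine at the end of a saturated chain. In a physicochemical assay for lipophilicity, using the shake flask method, measured as octanol-water partition, at pH 7.4 (on this read-out higher numbers stand for higher lipophilicity and lower numbers for lower lipophilicity), compound 3 gives 1.69. Compound 1 `COc1cc(/C=C/C(=O)Nc2ccccc2)ccc1OCCCCCN1CCCCC1` gives 1.65 in this assay, and compound 2 `COc1cc(/C=C/C(=O)Nc2ccccc2)ccc1OCCCCCN1CCCC1` gives 1.64. The three values sit together: a number 0.04 log units higher from compound 1 to compound 3 (within the scatter), a number 0.05 log units higher from compound 2 to compound 3 (within the scatter) and a number 0.01 log units lower from compound 1 to compound 2 (within the scatter), so no one of them can be set apart from the others on this read-out.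

Compound 4 `COc1cc(/C=C/C(=O)Nc2ccccc2)ccc1OCCCCCCCCCCN(C)C` is the unmeasured member. It differs from compound 3 as follows: 4-(dimethylamino)butyl in place of dimethylamino on a saturated chain carbon, six bonds along the chain from an oxygen on an aromatic ring. None of the three measured steps bears on this change; each of them swaps one amine for another at a chain of unchanged length, and each stayed within the scatter. The step to compound 4 is of a different kind, since it adds the counted chain carbons and leaves the amine as it was. Compound 4 is therefore expected to move beyond the scatter, upward, by a number 1.61 log units higher from compound 3 to compound 4 (beyond the scatter) in this assay. Compound 4 is estimated at 3.3, with a range from 2.6 to 4.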

Compound 4, partition coefficient: 1.8
The estimate for compound 4 lay 1.50 log units above the measured number; the whole stated range lies above it.
By their numbers in this assay, from the lowest: compounds 2, 1, 3 and 4 (each within the scatter of the next).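

In this assay, among these compounds, the change to 4-(dimethylamino)butyl in place of dimethylamino, on a saturated chain carbon, six bonds along the chain from an oxygen on an aromatic ring, gives a number 0.11 log units higher from compound 3 to compound 4 (within the scatter), which shows that this lengthening of the chain, a kind of change the earlier steps did not cover, stays within the scatter just as the amine swaps did. The two steps that alter the amine and the chain together read the same way, with a number 0.16 log units higher from compound 2 to compound 4 (within the scatter) and a number 0.15 log units higher from compound 1 to compound 4 (within the scatter), so on this read-out none of the four compounds can be set apart from the others. Nothing at hand speaks to why the chain carbons added in compound 4 leave the number within the scatter of compound 3.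

The compounds shown leave open whether a longer chain than that of compound 4, or a shorter one than that of compound 3, would stay within the scatter as well. They also leave open whether the same lengthening would read alike with piperidin-1-yl or pyrrolidin-1-yl at the chain end, or with a carboxylic acid there in place of the amine.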